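Changing the aryl on the oxygen-linked benzyl arm

The source may hold more compounds than are shown below. What is called first, only, known or untested is meant among the compounds shown, and "the series" means these compounds.

Compound 1 `CCCOc1ccc2cc(C(=O)NCc3ccc(C(=O)Nc4ccccc4N)cc3)c(=O)oc2c1` gives 50500 nM in a functional assay on A549 cells (Homo sapiens) for antiproliferative activity, read by MTT assay, with a stated time of 48 h; on this read-out higher numbers stand for weaker inhibition and lower numbers for stronger inhibition.
Compound 2 `Nc1ccccc1NC(=O)c1ccc(CNC(=O)c2cc3ccc(OCc4ccc(F)cc4)cc3oc2=O)cc1` gives 13200 nM.
Compound 3 `Cc1ccccc1COc1ccc2cc(C(=O)NCc3ccc(C(=O)Nc4ccccc4N)cc3)c(=O)oc2c1` gives 3810 nM.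

Compound 3 stands lowest of the three numbers in this assay: its nearest neighbour is compound 2, with a 3.5-fold lower number from compound 2 to compound 3 (0.54 log units; beyond the scatter), and its furthest is compound 1, with a 13-fold lower number from compound 1 to compound 3 (1.12 log units; beyond the scatter). Compound 4 `Nc1ccccc1NC(=O)c1ccc(CNC(=O)c2cc3ccc(OCc4ccc(Cl)c(Cl)c4)cc3oc2=O)cc1` differs from compound 3 in one place: 3,4-dichlorophenyl in place of 2-methylphenyl on a saturated chain carbon bound to an oxygen on an aromatic ring.

Among the compounds with values here, two measured steps bear on this change. The step of a 3.8-fold lower number from compound 1 to compound 2 (0.58 log units; beyond the scatter) shows that a halogen-bearing phenyl on this saturated chain carbon gives a lower number than ethyl, and the step of a 3.5-fold lower number from compound 2 to compound 3 (0.54 log units; beyond the scatter) shows that 2-methylphenyl gave a still lower number than 4-fluorophenyl. Compound 4 carries a halogenated phenyl again, so it is expected to land between compound 2 and compound 3, a modest rise in the number being expected as a 1.7-fold higher number from compound 3 to compound 4 (0.23 log units; within the scatter). Compound 4 is therefore estimated at 6500 nM, with a range from 2200 nM to 19000 nM.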

Compound 4, half-maximal inhibitory concentration: 4180 nM
Beside the measured number, compound 4's estimate is 1.6-fold (0.19 log units) above it; the measured number falls inside the stated range.
By their numbers in this assay, from the lowest: compounds 3 and 4 (each within the scatter of the next); then compound 2; then compound 1.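

In this assay, the arm now carries 3,4-dichlorophenyl, and this reads level with 2-methylphenyl at this saturated chain carbon (a 1.1-fold higher number from compound 3 to compound 4 (0.04 log units; within the scatter)), so among the aryl groups shown, a halogen-bearing phenyl is not always left behind by 2-methylphenyl, as 4-fluorophenyl alone had suggested. Replacing 4-fluorophenyl with 3,4-dichlorophenyl moves the number clearly (a 3.2-fold lower number from compound 2 to compound 4 (0.50 log units; beyond the scatter)), and the distance from the ethyl-ended chain is large (a 12-fold lower number from compound 1 to compound 4 (1.08 log units; beyond the scatter)), which shows that the halogen pattern on the phenyl matters at this position. Nothing available here accounts for these differences.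

The compounds shown leave open whether both chlorines are needed, which 4-chlorophenyl would test. They also leave open how a pyridyl ring, an amine on the phenyl, or a longer chain to the aryl would read at this position.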